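The source may hold more compounds than are shown below. What is called first, only, known or untested is meant among the compounds shown, and "the series" means these compounds.

For the measured compounds named here, compound 1 `CCOC(=O)c1cnn(-c2nc(-c3ccc(Cl)cc3)c(C#N)c(=O)n2C)c1N` is one of two compounds measured so far in a functional assay on microsomes for inhibition, with a stated time of 1 h; a higher number here means a weaker inhibitor, a lower number a stronger inhibitor. In this assay compound 1 gives 88 ug/mL, the lowest of the two numbers. The other measured compound, compound 2 `CSc1nc(-c2ccc(N(C)C)cc2)c(C#N)c(=O)n1C`, gives 98 ug/mL in this assay; this value and that of compound 1 lie within the usual scatter of each other, so the two numbers show no real separation. Going by the values given here, compound 2 shares only part of its framework with compound 1, and no single-point step between them is available.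

The next compound, compound 3 `CCOC(=O)c1cnn(-c2nc(-c3ccccc3O)c(C#N)c(=O)n2C)c1N`, differs from compound 1 in one place: 2-hydroxyphenyl in place of 4-chlorophenyl on an aromatic carbon. Among the compounds with values here, there is no measured step of this kind to lean on, so the expectation rests on compound 1 alone. Because compound 1 gives 88 ug/mL, the estimate for compound 3 is set close to it, and the expected step from compound 1 to compound 3 is a 1.0-fold higher number from compound 1 to compound 3 (0.01 log units; within the scatter), a change no larger than the scatter in either direction. Compound 3 is therefore estimated at 90 ug/mL, with a range from 40 ug/mL to 200 ug/mL.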

Compound 3, half-maximal inhibitory concentration: 57 ug/mL
Compound 3: middle estimate off by 1.6-fold (0.20 log units), on the high side; low and high end bracket the measured number.
By their numbers in this assay, from the lowest: compounds 3, 1 and 2 (each within the scatter of the next).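

In this assay, for the compounds shown here, placing 2-hydroxyphenyl where compound 1 carries 4-chlorophenyl, on the aromatic carbon ortho to a cyano group, gives a 1.5-fold lower number from compound 1 to compound 3 (0.19 log units; within the scatter) and so offers the first comparison of compounds that differ in one place. This position therefore takes a quite different aromatic group, one with 1 hydrogen-bond donor and 1 hydrogen-bond acceptor in place of 0 of each, without any real separation between the two numbers. No measurement at hand bears on what lies behind this result.

The step swaps chlorine for a hydroxyl oxygen and also moves the substituent around the phenyl ring, so it cannot tell the two changes apart; 4-hydroxyphenyl or 2-chlorophenyl at this position would begin to pull them apart. On these data alone, whether anything here can move the number beyond the scatter also stays open, and a group of another kind, such as an amine on the phenyl ring, a carboxylic acid, or a saturated ring like cyclohexyl in place of the phenyl, would test this.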